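A Morpholine Swap Tried on a Second Chromone Core

The source may report more compounds than this note shows. Statements on the series, on what has been measured and on what is new or still open speak of the compounds shown alone.

Of the compounds shown here, three have been measured in a functional assay on HEp-2 cells (Homo sapiens) for antiproliferative activity, read by MTT assay, with a stated time of 72 h; a higher number here means a weaker inhibitor, a lower number a stronger inhibitor. Compound 1 (`COc1ccc2occ(CSC(=S)N(C(C)C)C(C)C)c(=O)c2c1`) gives 8900 nM. Compound 2 (`COc1ccc2occ(CSC(=S)N3CCOCC3)c(=O)c2c1`) gives 4800 nM. Compound 3 (`CC(C)N(C(=S)SCc1cc(=O)c2ccccc2o1)C(C)C`) gives 13600 nM. The difference between the core of compound 1 and the core of compound 3 is not broken down here.

The change from compound 1 to compound 2 is morpholin-4-yl in place of diisopropylamino on a thiocarbonyl carbon, and that step was a 1.9-fold lower number from compound 1 to compound 2 (0.27 log units; within the scatter). The very same change, at the same place, now turns compound 3 into compound 4 (`O=c1cc(CSC(=S)N2CCOCC2)oc2ccccc12`): morpholin-4-yl in place of diisopropylamino on a thiocarbonyl carbon.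

For compound 4 in this assay a number somewhat lower than that of compound 3 is expected, because the earlier step gave a 1.9-fold lower number from compound 1 to compound 2 (0.27 log units; within the scatter). The expected step is a 1.9-fold lower number from compound 3 to compound 4 (0.28 log units; within the scatter). This rests on a single earlier pair on a different core, so the estimate is held loosely. The expected value for compound 4 is 7200 nM, with a range from 3500 nM to 15000 nM.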

Compound 4, half-maximal inhibitory concentration: > 25000 nM
Compound 4 was reported as a limit; the forecaster's own chance of this, stated with the estimate: 5%; middle value at least 3.4-fold (0.54 log units) from the limit.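

In this assay compound 4 is reported as a limit, > 25000 nM, and not as an exact number. The step on this core reads an at least 1.8-fold higher number from compound 3 to compound 4 (0.26 log units; that floor lies within the scatter), and set beside the earlier step, the change does not carry over unaltered from one core to the other: the same change on two cores in this assay, a 1.9-fold lower number (0.27 log units; within the scatter) from compound 1 to compound 2 and an at least 1.8-fold higher number (0.26 log units; that floor lies within the scatter) from compound 3 to compound 4, at least 3.4-fold (0.53 log units) apart, beyond the scatter of two such steps Each step taken alone lies within the scatter and only the gap between them lies beyond it, so this shows that the outcome of the swap differed between these two cores, but with a single pair on each core it does not show how far apart compound 3 and compound 4 truly lie, or why the cores differ.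

Going by these compounds, it remains open whether this gap is tied to morpholin-4-yl or also appears with other amines, such as piperidin-1-yl or dimethylamino, on the thiocarbonyl carbon of both cores. Also open, on these data alone, is which part of the difference between the core of compound 1 and the core of compound 3 goes with the gap.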